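The compounds below may be only part of what the source reports. "The series", "measured", "known", "first", "only" and "open" are said of these compounds alone.

Of the compounds shown here, three built on one shared core have been tested in an assay (strain Sprague-Dawley) for inhibition of Amine oxidase [flavin-containing] B (Rattus norvegicus), read by spectrophotometry, with a stated time of 5 min, tested at 10 uM; on this read-out lower numbers stand for less inhibition and higher numbers for more inhibition at the one concentration tested (going by the name of the read-out). Compound 1 `CNC(=O)/C=C1/COc2cc(OS(=O)(=O)c3cccc(Cl)c3)ccc21` gives 0% in this assay, compound 2 `CNC(=O)/C=C1/COc2cc(OS(=O)(=O)c3cccc(C#N)c3)ccc21` gives 0%, and compound 3 `CNC(=O)/C=C1/COc2cc(OS(=O)(=O)c3ccc(Cl)cc3)ccc21` gives 6%. Compound 3 stands alongside the other two rather than apart from them: the step of a number 6 percentage points higher from compound 1 to compound 3 (within the scatter) and the step of a number 6 percentage points higher from compound 2 to compound 3 (within the scatter) both remain inside the usual scatter, as does the step of no change at the digits printed from compound 1 to compound 2 (within the scatter). Compound 4 `CNC(=O)/C=C1/COc2cc(OS(=O)(=O)c3ccc(S(C)(=O)=O)cc3)ccc21` has not yet been measured in this assay; it differs from compound 3 in one place: methylsulfonyl in place of chloro on an aromatic carbon. All three measured steps bear on this change, since each of them also exchanges one group on the phenyl ring carried by the sulfonyl sulfur, and none of them shifted the inhibition beyond the scatter. The same outcome is therefore expected here: the step of a number 3 percentage points lower from compound 3 to compound 4 (within the scatter) is expected to stay within the scatter. Compound 4 is accordingly estimated to give 3% in this assay, with a range from 0% to 15%.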

Compound 4, a percentage reported as inhibition, at one concentration (the size of the read-out at that concentration, not a potency): 0%
For compound 4 the middle estimate is 3 percentage points above the measured one; low and high end bracket the measured number.
By their numbers in this assay, from the lowest: compounds 1, 2, 4 and 3 (each within the scatter of the next).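

In this assay the exchange of chloro for methylsulfonyl on an aromatic carbon, para to a large group, gives a number 6 percentage points lower from compound 3 to compound 4 (within the scatter) and so stays inside the scatter. The earlier steps shown here exchanged only chloro and cyano or shifted the chloro, whereas here a group of 4 heavy atoms with 2 hydrogen-bond acceptors replaces a single chlorine with none, and the read-out still does not separate the two compounds. Nothing in the data shown accounts for this flat result.

With every value at a single concentration and within the scatter, no group at this place has yet been seen to give clear inhibition. On these data alone, whether an amine, a carboxylic acid or a longer alkyl chain there would move the read-out remains open.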